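This account rests on a few compounds, and the source may have more. Where it says the series, first, only, none or still open, it means among the compounds named here.

In a functional assay on CHO-K1 cells with Glucose-dependent insulinotropic receptor (Homo sapiens) as the target, read by a luciferase reporter, with a stated time of 5 h (on this read-out lower numbers stand for smaller maximal responses and higher numbers for larger maximal responses), the three measured compounds stand as follows:
compound 1 `CSC(=O)N1CCC(Oc2ncnc3c2CCN3c2ccc(S(C)(=O)=O)cc2F)CC1` gives 135%
compound 2 `CCSC(=O)N1CCC(Oc2ncnc3c2CCN3c2ccc(S(C)(=O)=O)cc2F)CC1` gives 128%
compound 3 `CCS(=O)(=O)N1CCC(Oc2ncnc3c2CCN3c2ccc(S(C)(=O)=O)cc2F)CC1` gives 51%

Compound 2 differs from compound 1 by one change, (methyl in place of hydrogen on a saturated chain carbon bound to a sulfur), and that change produced a number 7 percentage points lower from compound 1 to compound 2 (within the scatter). Compound 4 `CC(C)S(=O)(=O)N1CCC(Oc2ncnc3c2CCN3c2ccc(S(C)(=O)=O)cc2F)CC1` has not yet been measured. It differs from compound 3 by methyl in place of hydrogen on a saturated chain carbon bound to a saturated chain carbon and a sulfonyl sulfur. Within the data shown here, this is the same kind of change as the one from compound 1 to compound 2, but the surroundings differ: in the earlier pair the carbon is bound to a sulfur, whereas here it is bound to a saturated chain carbon and a sulfonyl sulfur. The two cores themselves differ by ethylsulfonyl in place of (methylsulfanyl)carbonyl on an amine nitrogen in a ring.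

For compound 4 the expected step in this assay is a number 1 percentage points lower from compound 3 to compound 4 (within the scatter), a small one, which rests on compound 1 and compound 2 having shown a number 7 percentage points lower from compound 1 to compound 2 (within the scatter). The estimate for compound 4 is therefore 50%, expected to fall between 30% and 75%.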

Compound 4, largest response reached (reported as percent of maximum), in percent of the reference or control that the assay uses: 62%
Compound 4: middle estimate off by 12 percentage points, on the low side, within the range that was stated.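

In this assay, the methyl that turns ethylsulfonyl into isopropylsulfonyl gave a number 11 percentage points higher from compound 3 to compound 4 (beyond the scatter), so the same change did not behave alike on the two cores: the same change on two cores in this assay, a number 7 percentage points lower (within the scatter) from compound 1 to compound 2 and a number 11 percentage points higher (beyond the scatter) from compound 3 to compound 4, 18 percentage points apart, beyond the scatter of two such steps. This shows that the step on the core of compound 1 was no safe guide to the step on the core of compound 3, but with one pair per core it does not show why they differ or give a general rule. Replacing either sulfur-bearing carbonyl group on the amine nitrogen in a ring with isopropylsulfonyl gave much larger steps, a number 66 percentage points lower from compound 2 to compound 4 (beyond the scatter) and a number 73 percentage points lower from compound 1 to compound 4 (beyond the scatter).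

Still open, going by these compounds, is how a longer chain such as butyl or a cyclopropyl group would behave on the sulfonyl. On these data alone, it is also open whether an amide carbonyl on that nitrogen would match the sulfur-bearing carbonyl groups.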